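Chloro to fluoro on the methyl compound

A few compounds are considered here, and "the series" means these few. Any claim that something is new, unique, unknown or untested is made for them only; others in the source may bear on it.

Within the data shown here, in a functional assay on PC-3 cells (Homo sapiens) (a lower number here means a stronger inhibitor of growth, a higher number a weaker inhibitor of growth), compound 2 (`Cc1cnc2nc(-c3ccc(Cl)cc3)cc(O)c2c1`) gives 1150 nM, the lower of the two numbers so far, while compound 1 (`Oc1cc(-c2ccc(Cl)cc2)nc2ncccc12`) gives 47900 nM. Among the measured compounds shown here, the one measured step, a 42-fold lower number from compound 1 to compound 2 (1.62 log units; beyond the scatter), is large, but it is methyl in place of hydrogen on an aromatic carbon, so it only loosely bears on the next change. Compound 3 (`Cc1cnc2nc(-c3ccc(F)cc3)cc(O)c2c1`) has fluoro in place of chloro on an aromatic carbon. No halogen exchange has been measured, so only a modest rise in the number is expected. The expected step is a 1.6-fold higher number from compound 2 to compound 3 (0.19 log units; within the scatter). Compound 3 is estimated at 1800 nM, within 600 nM to 5500 nM.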

Compound 3, concentration for 50% growth inhibition: 25700 nM
For compound 3 the middle estimate is 14-fold (1.15 log units) below the measured one, outside the stated range (above it).
By their numbers in this assay, from the lowest: compound 2; then compounds 3 and 1 (each within the scatter of the next).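

With methyl held in place, the position on the aromatic carbon para to a large group proves sensitive in this assay: exchanging one halogen for another gives a 22-fold higher number from compound 2 to compound 3 (1.35 log units; beyond the scatter), so chloro and fluoro are not interchangeable here. A one-atom change at this position therefore produces a large step, and chloro is the better of the two on the methyl compound. Nothing measured here accounts for the step. From the compounds shown here alone, whether chloro keeps this advantage without the methyl remains open. So does how bromo, methoxy or trifluoromethyl would read at this position.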